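The source may report more compounds than this note shows. Statements on the series, on what has been measured and on what is new or still open speak of the compounds shown alone.

Of the compounds shown here, three sharing one core have been tested in a functional assay on SK-OV-3 cells (Homo sapiens) for inhibition, read by sulforhodamine B assay, with a stated time of 48 h; a higher number here means a weaker inhibitor of growth, a lower number a stronger inhibitor of growth. Compound 3 `Nc1cc(N)c2nc(-c3ccccc3)c(NCc3ccc(Cl)c(Cl)c3)nc2c1` gives 36300 nM in this assay, the lowest of the two numbers available. Compound 1 `Nc1cc(N)c2nc(-c3ccccc3)c(Oc3ccc(Cl)c(Cl)c3)nc2c1` gives 66100 nM in this assay, a gap that falls within the scatter of the method, so the two cannot be ranked against each other. Compound 2 `CCOC(=O)[C@H](CCC(=O)O)NC(=O)c1ccc(CNc2nc3cc(N)cc(N)c3nc2-c2ccccc2)cc1` is reported in this assay only as a limit, < 100000 nM, not as a number. Compound 4 `COc1ccc(CNc2nc3cc(N)cc(N)c3nc2-c2ccccc2)cc1OC` has not been measured; it differs from compound 3 by 3,4-dimethoxyphenyl in place of 3,4-dichlorophenyl on a saturated chain carbon bound to a nitrogen on an aromatic ring. Within the data shown here, no measured pair mirrors this change, so the expected step is a 1.5-fold higher number from compound 3 to compound 4 (0.18 log units; within the scatter), a shift hardly beyond the scatter. Compound 4 is therefore expected to give about 55000 nM in this assay, within 22000 nM to 140000 nM.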

Compound 4, concentration for total growth inhibition: 46800 nM
Compound 4: middle estimate off by 1.2-fold (0.07 log units), on the high side, within the range that was stated.
By their numbers in this assay, from the lowest: compounds 3, 4 and 1 (each within the scatter of the next).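

Among the compounds shown, this is the only comparison that differs in one place: 3,4-dimethoxyphenyl in place of 3,4-dichlorophenyl on a saturated chain carbon bound to a nitrogen on an aromatic ring gives, in this assay, a 1.3-fold higher number from compound 3 to compound 4 (0.11 log units; within the scatter). At this position, then, the two substituted rings cannot be told apart in this read-out. Compound 2 remains a limit, not a number, in this assay: the limit of < 100000 nM in this assay, at which 1 of the 4 values shown sits.

On these data alone, whether an amine or a carboxylic acid on this ring, or a longer chain on that nitrogen, would produce a step beyond the scatter remains open.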